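This account rests on a few compounds, and the source may have more. Where it says the series, first, only, none or still open, it means among the compounds named here.

Measured compounds: compound 1 `CC(C)[C@H](NC(=O)c1ccc(C(=O)Nc2ccc3c(c2)C(C)(C)CCC3(C)C)cc1)C(=O)OCc1c(-c2ccccc2)no[n+]1[O-]` with 192000 nM in a functional assay on K562 cells (Homo sapiens) for antiproliferative activity, read by MTT assay, with a stated time of 48 h; a lower number here means a stronger inhibitor, a higher number a weaker inhibitor; compound 2 `CC(C)C[C@H](NC(=O)c1ccc(C(=O)Nc2ccc3c(c2)C(C)(C)CCC3(C)C)cc1)C(=O)OCc1c(-c2ccccc2)no[n+]1[O-]` with 64000 nM in this assay.

Compound 2 holds the lowest number of the two, with compound 1 giving a higher one (a 3.0-fold lower number from compound 1 to compound 2 (0.48 log units; beyond the scatter)). Compound 3 `C[C@H](NC(=O)c1ccc(C(=O)Nc2ccc3c(c2)C(C)(C)CCC3(C)C)cc1)C(=O)OCc1c(-c2ccccc2)no[n+]1[O-]` is not yet measured; it differs from compound 2 by hydrogen in place of isopropyl on a saturated chain carbon, two bonds along the chain from an amide-type nitrogen and a carbonyl carbon. Within the data shown here, only the step from compound 1 to compound 2 bears on this change, and it showed a lower number when the side chain grew (a 3.0-fold lower number from compound 1 to compound 2 (0.48 log units; beyond the scatter)). Shrinking the chain further is therefore expected to raise the number, a step of about a 5.5-fold higher number from compound 2 to compound 3 (0.74 log units; beyond the scatter). Compound 3 is estimated at 350000 nM, within 120000 nM to 1000000 nM.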

Compound 3, half-maximal inhibitory concentration: 60400 nM
Estimate against measurement, compound 3: 5.8-fold (0.76 log units) above; measured number outside the range, below it.
By their numbers in this assay, from the lowest: compounds 3 and 2 (each within the scatter of the next); then compound 1.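

Swapping isobutyl for methyl on this chain carbon changes nothing that can be told apart in this assay (a 1.1-fold lower number from compound 2 to compound 3 (0.03 log units; within the scatter)), so the number does not simply follow the length of the side chain. Compound 1, with isopropyl, is the one that stands apart, as methyl in its place also shows (a 3.2-fold lower number from compound 1 to compound 3 (0.50 log units; beyond the scatter)). Nothing available explains why isopropyl differs. Still open, as far as these compounds go, is how a longer chain, an amine or a carboxylic acid at this carbon would behave. With so few side chains, it is also unclear whether the isopropyl result is an isolated case.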